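The source may hold more compounds than are shown below. What is called first, only, known or untested is meant among the compounds shown, and "the series" means these compounds.

Measured in a functional assay on MCF7 cells (Homo sapiens) for antiproliferative activity, read by MTT assay, with a stated time of 48 h; on this read-out lower numbers stand for stronger inhibition and higher numbers for weaker inhibition:
Compound 1 `COc1ccc(C(=O)c2ccc3c(c2)C=CC(C)(C)O3)c(NC(=O)CO)c1`: 200 nM
Compound 2 `CNCC(=O)Nc1cc(OC)ccc1C(=O)c1ccc(OC)c2c1C=CC(C)(C)O2`: 3040 nM
Compound 3 `CCNCC(=O)Nc1cc(OC)ccc1C(=O)c1ccc(OC)c2c1C=CC(C)(C)O2`: 7230 nM

Among the compounds with values here, compound 1 has the lowest number of the three, so it is the most potent compound measured so far. Compound 4 `CCNCC(=O)Nc1cc(OC)ccc1C(=O)c1ccc2c(c1)C=CC(C)(C)O2` keeps the core of compound 1 and changes the side chain, with ethylamino in place of hydroxy on a saturated chain carbon bound to a carbonyl carbon.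

Within the data shown here, no measured step covers this exchange directly. The closest evidence is a 2.4-fold higher number from compound 2 to compound 3 (0.38 log units; beyond the scatter), a modest rise that comes from lengthening the group on the amine nitrogen, on a core that differs from that of compound 1. Compound 4 carries the same ethylamino group as compound 3, and compound 3 gives 7230 nM, but its core differs too, and the data cannot separate the two changes. In this assay, a clear rise from compound 1 is therefore expected, though probably not all the way to the number of compound 3.

The estimated step is a 5.0-fold higher number from compound 1 to compound 4 (0.70 log units; beyond the scatter). For compound 4 the expected value is 1000 nM, with an estimated range from 250 nM to 4500 nM.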

Compound 4, half-maximal inhibitory concentration: 6310 nM
Estimate against measurement, compound 4: 6.3-fold (0.80 log units) below; measured number above the stated range.
By their numbers in this assay, from the lowest: compound 1; then compound 2; then compounds 4 and 3 (each within the scatter of the next).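

In this assay, putting ethylamino in place of hydroxy on a saturated chain carbon bound to a carbonyl carbon gives a 32-fold higher number from compound 1 to compound 4 (1.50 log units; beyond the scatter), a large step and the first one shown at this place with the core of compound 1 held fixed. The core of compound 1 therefore does not keep the number low by itself: with the same ethylamino chain, compound 4 gives 6310 nM and compound 3 gives 7230 nM, two values within the usual scatter of each other despite their different cores. Nothing measured here bears on the reason for the size of this step.

The compounds shown leave open whether a plain amino group or a methoxy group at this place on the core of compound 1 would give a number nearer that of compound 1 or that of compound 4. They also leave open whether hydroxy on the core of compound 3 would give a number as low as that of compound 1, which would show how much of its low number depends on that core.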